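Three Halogenated Benzyl Groups and a Fourth, Untested

The compounds below may be only part of what the source reports. "The series", "measured", "known", "first", "only" and "open" are said of these compounds alone.

Measured in an in vitro assay on HEK293 cells for displacement of a labelled ligand from adenosine receptor A2b (Homo sapiens); a higher number here means a weaker inhibitor, a lower number a stronger inhibitor:
- compound 1, `CCCn1c(=O)c2nc(-c3cnn(Cc4cc(C(F)(F)F)ccc4Cl)c3)[nH]c2n(CCC)c1=O`: 22 nM
- compound 2, `CCCn1c(=O)c2nc(-c3cnn(Cc4cc(F)ccc4Cl)c3)[nH]c2n(CCC)c1=O`: 4800 nM
- compound 3, `CCCn1c(=O)c2nc(-c3cnn(Cc4cc(Cl)ccc4Cl)c3)[nH]c2n(CCC)c1=O`: 29 nM

All three share one core and differ only in the substituents on the benzyl ring. Compound 3 sits close to compound 1, the two within the usual scatter of each other, while compound 2 lies far from both: a 170-fold lower number from compound 2 to compound 3 (2.22 log units; beyond the scatter), and a 220-fold higher number from compound 1 to compound 2 (2.34 log units; beyond the scatter).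

Compound 4, `CCCn1c(=O)c2nc(-c3cnn(Cc4c(F)cc(F)cc4F)c3)[nH]c2n(CCC)c1=O`, has not yet been measured in this assay. Compared with compound 3 the change is 2,4,6-trifluorophenyl in place of 2,5-dichlorophenyl on a saturated chain carbon bound to an aromatic nitrogen.

Among the measured compounds shown here, two measured steps bear on this. Going from compound 1 to compound 2, and from compound 2 to compound 3, shows that a ring carrying fluoro where chloro or trifluoromethyl once stood gives a much weaker inhibitor; compound 2 is the only fluoro-bearing example so far. Compound 4 carries only fluoro on that ring, none of the chloro or trifluoromethyl seen in compound 1 and compound 3. A large step upward in this assay is therefore expected for compound 4, a 100-fold higher number from compound 3 to compound 4 (2.01 log units; beyond the scatter), though the exact size is uncertain with a single fluoro example. The estimate for compound 4 is 3000 nM, within a range from 400 nM to 20000 nM.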

Compound 4, inhibition constant: 650 nM
Compound 4: middle estimate off by 4.6-fold (0.66 log units), on the high side, within the range that was stated.
By their numbers in this assay, from the lowest: compounds 1 and 3 (each within the scatter of the next); then compound 4; then compound 2.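

In this assay, a ring carrying only fluoro does not land at the weak end of the series: the move to 2,4,6-trifluorophenyl still costs a great deal against the chlorine-bearing 2,5-dichlorophenyl, at a 22-fold higher number from compound 3 to compound 4 (1.35 log units; beyond the scatter), and against the ring with chloro and trifluoromethyl, at a 30-fold higher number from compound 1 to compound 4 (1.47 log units; beyond the scatter), yet it gains ground on the ring with one chloro and one fluoro, at a 7.4-fold lower number from compound 2 to compound 4 (0.87 log units; beyond the scatter). Compound 2 therefore goes against the simple idea that keeping a chloro on the ring is enough to hold on to a low number, since compound 4 has no chloro at all and still gives the lower number of the two; the whole set of substituents on the ring counts, not the presence of any one halogen. Nothing measured here explains why the ring with three fluoro groups ends up ahead of the ring with one chloro and one fluoro.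

On these data alone, with no ring here carrying two fluoro groups, it stays open how much each fluoro of compound 4 contributes. Also open, as far as these compounds go, is how this assay would respond to a benzyl ring bearing a methoxy group, a nitrile or an amine in place of these halogens.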